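The source may report more compounds than this note shows. Statements on the series, on what has been measured and on what is new or still open speak of the compounds shown alone.

Measured compounds:
compound 1, `CCCCN(c1nc2ccccc2o1)[C@H](C)c1ccc(-c2ccccc2-c2nnn[nH]2)cc1` — 29.2 nM
compound 2, `C[C@H](c1ccc(-c2ccccc2-c2nc(=O)o[nH]2)cc1)N(CC1CC1)c1nc2c(C(=O)O)cccc2o1` — 7710 nM
compound 3, `CCCCN(c1nc2c(C(=O)O)cccc2o1)[C@H](C)c1ccc(-c2cc(Cl)ccc2-c2nc(=O)o[nH]2)cc1` — 677 nM

In an ADME assay on the whole organism (Macaca fascicularis) for pharmacokinetics, read by LC-MS, using cassette dosing, at a dose of 1 mg/kg by the oral route (on this read-out higher numbers stand for higher exposure at the dose given and lower numbers for lower exposure), compound 1 gives 29.2 nM, the lowest of the three numbers. Compound 3 stands nearest to it with 677 nM, and compound 2 furthest with 7710 nM; both gaps lie beyond the scatter. Compounds 2 and 3 differ from compound 1 in more than one place, so no single step can be read from them; their values show only that higher exposure is reached within this series.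

Compound 4, `CCCCN(c1nc2c(CO)cccc2o1)[C@H](C)c1ccc(-c2ccccc2-c2nnn[nH]2)cc1`, differs from compound 1 in one place: hydroxymethyl in place of hydrogen on an aromatic carbon. Within the data shown here, no measured pair shows this exact step, so its size is unknown. Given that compound 3 reaches 677 nM and compound 2 reaches 7710 nM, an upward step is expected, though a modest one; a 3.1-fold higher number from compound 1 to compound 4 (0.49 log units; beyond the scatter) is the estimated step from compound 1 to compound 4. Compound 4 is expected to give 90 nM, within a range from 20 nM to 500 nM.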

Compound 4, maximal plasma concentration: 20.7 nM
Compound 4: the middle estimate sits 4.3-fold (0.64 log units) above what was measured; measured number inside the range.
By their numbers in this assay, from the lowest: compounds 4 and 1 (each within the scatter of the next); then compound 3; then compound 2.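

In this assay, among these compounds, the first single-place change at this position can be read: hydroxymethyl in place of hydrogen on an aromatic carbon gives a 1.4-fold lower number from compound 1 to compound 4 (0.15 log units; within the scatter) and so leaves the maximal plasma concentration indistinguishable from that of compound 1. Adding these 2 heavy atoms, with 1 hydrogen-bond donor and 1 hydrogen-bond acceptor, therefore produces no measurable shift at this position in this assay. No measured information available here explains this result.

The steps from compound 1 or compound 4 to compound 2 and compound 3 cannot be read, so what separates those numbers remains unresolved. On these data alone, it also remains open whether an amine or a longer chain such as hydroxyethyl on this aromatic carbon would give a different number.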